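Compound 3 to compound 4: phenyl replaced by chloro

This account rests on a few compounds, and the source may have more. Where it says the series, first, only, none or still open, it means among the compounds named here.

Measured in a functional assay on A2780 cells (Homo sapiens) for inhibition, read by MTT assay, with a stated time of 72 h; a lower number here means a stronger inhibitor, a higher number a weaker inhibitor:
- compound 1 `O=C1/C(=C\c2ccccc2)c2c(ncn2COCc2ccccc2)CCN1Cc1ccccc1`: 20400 nM
- compound 2 `Cc1ccc(CN2CCc3ncn(COCc4ccccc4)c3/C(=C/c3ccccc3)C2=O)cc1`: 21200 nM
- compound 3 `O=C1/C(=C\c2ccccc2)c2c(ncn2COCc2ccccc2)CCN1Cc1ccc(-c2ccccc2)cc1`: 48300 nM

Compound 3 has the highest number of the three and is the weakest inhibitor so far. The next compound to be measured is compound 4 `O=C1/C(=C\c2ccccc2)c2c(ncn2COCc2ccccc2)CCN1Cc1ccc(Cl)cc1`. The change is chloro in place of phenyl on an aromatic carbon, or 4-phenylphenyl to 4-chlorophenyl.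

Going by the values given here, no chloro compound has been measured, so the closest evidence comes from the other changes at this place. Replacing hydrogen with methyl gives a 1.0-fold higher number from compound 1 to compound 2 (0.02 log units; within the scatter). Phenyl in place of hydrogen gives a 2.4-fold higher number from compound 1 to compound 3 (0.37 log units; beyond the scatter), and phenyl in place of methyl gives a 2.3-fold higher number from compound 2 to compound 3 (0.36 log units; beyond the scatter). Only the phenyl steps exceed the scatter, and both are modest. Losing the phenyl is therefore expected to undo a step of that size, with chloro falling in with hydrogen and methyl. The expected change in this assay is a 2.4-fold lower number from compound 3 to compound 4 (0.38 log units; beyond the scatter), a modest move to a lower number. For compound 4 the estimated value is 20000 nM, with an expected range of 10000 nM to 40000 nM.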

Compound 4, half-maximal inhibitory concentration: 22200 nM
The estimate for compound 4 lay 1.1-fold (0.05 log units) below the measured number, and the stated range covers the measured number.
By their numbers in this assay, from the lowest: compounds 1, 2 and 4 (each within the scatter of the next); then compound 3.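

In this assay, the higher number seen with the 4-phenylphenyl group does not carry over to 4-chlorophenyl: chloro in place of phenyl gives a 2.2-fold lower number from compound 3 to compound 4 (0.34 log units; beyond the scatter). Chloro cannot be told apart from methyl (a 1.0-fold higher number from compound 2 to compound 4 (0.02 log units; within the scatter)) or from hydrogen (a 1.1-fold higher number from compound 1 to compound 4 (0.04 log units; within the scatter)), so this place accepts a single chlorine without a readable change, and among the four compounds only compound 3 stands apart. No measurement among the data shown gives a cause for the phenyl step.

On these data alone, whether an amine, a methoxy group or a carboxylic acid at this place would stay level with hydrogen, methyl and chloro remains open. All four compounds vary only this one place, so whether the steps hold with changes elsewhere on the shared core is also unknown.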